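The source may hold more compounds than are shown below. What is called first, only, known or untested is meant among the compounds shown, and "the series" means these compounds.

Measured so far:
- compound 1, `COc1ccc(/C=N/NC(=O)c2cc(OC)c(OC)c(OC)c2)c(OC)c1`: 22.2%
- compound 2, `COc1cc(C2=NN(C(C)=O)C(c3ccc(F)c(F)c3)O2)cc(OC)c1OC`: 46.9%

In a functional assay on PC-3 cells (Homo sapiens) for antiproliferative activity, read by MTT assay, tested at 5 uM (on this read-out lower numbers stand for a weaker effect and higher numbers for a stronger effect at the one concentration tested), compound 2 gives the higher of the two numbers, and its gap to compound 1 lies beyond the usual scatter. Compound 3 is `COc1cc(C2=NN(C(C)=O)C(c3cccc(C(F)(F)F)c3)O2)cc(OC)c1OC`, not yet measured. It differs from compound 2 in one place: 3-(trifluoromethyl)phenyl in place of 3,4-difluorophenyl on a saturated ring carbon. For the measured compounds named here, with no measured pair showing what such a change does, no step beyond the scatter is expected in either direction. Compound 3 is therefore estimated at 45%, within a range from 25% to 65%, which as a step means a number 1.9 percentage points lower from compound 2 to compound 3 (within the scatter) expected.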

Compound 3, a percentage reported as inhibition, at one concentration (the size of the read-out at that concentration, not a potency): 43.6%
Estimate against measurement, compound 3: 1.4 percentage points above; measured number inside the range.
By their numbers in this assay, from the lowest: compound 1; then compounds 3 and 2 (each within the scatter of the next).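

In this assay, putting 3-(trifluoromethyl)phenyl in place of 3,4-difluorophenyl on the saturated ring carbon gives a number 3.3 percentage points lower from compound 2 to compound 3 (within the scatter). For the compounds shown here, this is the first measured swap at this position, and it shows that these two aromatic groups, which differ by two heavy atoms, cannot be told apart here. Nothing available explains why the two numbers fall so close together. On these data alone, it remains open whether an amine or a carboxylic acid on this phenyl ring would also fall within the scatter. Replacing the whole ring with a longer carbon chain is equally untested in the compounds shown.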